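Series notes: removal of the methyl on the triazole aryl

This account rests on a few compounds, and the source may have more. Where it says the series, first, only, none or still open, it means among the compounds named here.

Measured compounds:
compound 1 `C=C1C[C@]23C[C@@]1(O)CC[C@@H]2c1cccc(C)c1[C@@H]3Cn1cc(-c2ccc(C)cc2)nn1` — in a functional assay on A549 cells (Homo sapiens) for cytotoxicity, read by MTT assay, with a stated time of 4 days (on this read-out lower numbers stand for stronger inhibition and higher numbers for weaker inhibition), compound 1 gives > 20000 nM, a limit of the assay rather than a number.
compound 2 `C=C1C[C@]23C[C@@]1(O)CC[C@H]2c1ccc(OS(=O)(=O)c2ccc(C)cc2)c(C)c1[C@@H]3Cn1cc(-c2ccc(C)cc2)nn1` — compound 2 gives > 20000 nM, again a limit.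
compound 3 `C=C1C[C@]23C[C@@]1(O)CC[C@H]2c1cc(Br)c(O)c(C)c1[C@@H]3Cn1cc(-c2ccc(Cl)cc2)nn1` — compound 3 gives 10500 nM.

Compound 1 thus sits at the edge of what this assay reports: the limit of > 20000 nM in this assay, at which 2 of the 3 values shown sit. Only compound 3 returns a number, and it lies not far from that edge. Among the compounds with values here, no pair of these three differs in a single place, so no measured step is available, and what the values show is only that two compounds give limits and one gives a weak number.

Within the data shown here, compound 4 `C=C1C[C@]23C[C@@]1(O)CC[C@@H]2c1cccc(C)c1[C@@H]3Cn1cc(-c2ccccc2)nn1` is the one compound not yet measured. It differs from compound 1 by hydrogen in place of methyl on an aromatic carbon. Among the measured compounds shown here, no measured pair covers this change, and the shared core of compound 1 gives only a limit, so there is no basis for expecting a step beyond the scatter in either direction. The expected step that the limit leaves unreadable from compound 1 to compound 4 is therefore essentially none. Compound 4 is expected to give about 25000 nM in this assay, with a range from 10000 nM to 60000 nM, and most likely it is reported as a limit as compound 1 is.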

Compound 4, half-maximal inhibitory concentration: > 20000 nM
Compound 4 ended at the assay's limit; the forecaster's own chance of this, stated with the estimate: 70%; the middle value is on the limit's open side.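

Compound 1 and compound 4 both stand at a limit of this assay rather than at a number, so no step can be read for the change from 4-methylphenyl to phenyl: the limit of > 20000 nM in this assay, at which 3 of the 4 values shown sit.

The compounds shown leave open whether this change shifts the read-out of this assay at all, and in which direction.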